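This account rests on a few compounds, and the source may have more. Where it says the series, first, only, none or still open, it means among the compounds named here.

Compound 1 `NC(=O)NCCCCN(C[C@H]1Cc2ncccc2CN1)[C@H]1CCCc2cccnc21`: 7 nm/s
Compound 2 `CN(C)CCCCN(C[C@H]1Cc2ncccc2CN1)[C@H]1CCCc2cccnc21`: 2 nm/s
Compound 3 `c1cnc2c(c1)CN[C@@H](CN(CCCCNC1CCOCC1)[C@H]1CCCc3cccnc31)C2`: 2 nm/s

All three values come from an ADME assay for permeability, using PAMPA, with a stated time of 4 h, at pH 5.5; on this read-out higher numbers stand for higher permeability and lower numbers for lower permeability. Compound 3, at 2 nm/s, stands level with compound 2, as the comparison shows no change at the digits printed from compound 2 to compound 3 (within the scatter). Both sit under compound 1, with a 3.5-fold lower number from compound 1 to compound 3 (0.54 log units; beyond the scatter) and, for the other pair, a 3.5-fold lower number from compound 1 to compound 2 (0.54 log units; beyond the scatter).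

The next structure is compound 4 `CN(CCCCN(C[C@H]1Cc2ncccc2CN1)[C@H]1CCCc2cccnc21)C1CCOCC1`, which carries methyl in place of hydrogen on an amine nitrogen. Within the data shown here, no measured step isolates this exact change. The two modest steps away from compound 1 both remove its carbamoyl-bearing ureido group, a different change from the one at hand, so they bear on it only weakly. The closest evidence is the pair of compound 2 and compound 3, which differ by dimethylamino against (oxan-4-yl)amino and show no change at the digits printed from compound 2 to compound 3 (within the scatter). Among the measured compounds shown here, compound 4 combines the methyl-bearing amine of the one with the oxan-4-yl group of the other, so its number is expected to stay close to theirs. No step beyond the scatter is expected in this assay, and the estimated step is a 1.3-fold higher number from compound 3 to compound 4 (0.10 log units; within the scatter). For compound 4 the estimate is 2.5 nm/s, with an expected range from 1 nm/s to 6 nm/s.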

Compound 4, apparent permeability: 15 nm/s
Compound 4: the middle estimate sits 6.0-fold (0.78 log units) below what was measured; the measured number lies above the stated range.
By their numbers in this assay, from the lowest: compounds 2 and 3 (each within the scatter of the next); then compound 1; then compound 4.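

In this assay, methyl in place of hydrogen on the amine nitrogen whose other neighbours are a saturated chain carbon and a saturated ring carbon gives a clear rise (a 7.5-fold higher number from compound 3 to compound 4 (0.88 log units; beyond the scatter)), so a change of a single carbon at this position moves the number beyond the scatter. Oxan-4-yl also counts at this nitrogen when methyl sits on it (a 7.5-fold higher number from compound 2 to compound 4 (0.88 log units; beyond the scatter)), although the earlier comparison of dimethylamino with (oxan-4-yl)amino had shown nothing (no change at the digits printed from compound 2 to compound 3 (within the scatter)), so the effect of each group here depends on what else the nitrogen carries. Both earlier steps away from the ureido group had lowered the number, but methyl(oxan-4-yl)amino in its place raises it (a 2.1-fold higher number from compound 1 to compound 4 (0.33 log units; beyond the scatter)), which puts compound 4 at the top of the set.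

Nothing shown here gives a reason for these steps. The compounds shown leave open whether ethyl or a longer chain on this nitrogen would carry the number further, and whether a ring other than oxan-4-yl, such as cyclohexyl or piperidin-4-yl, would behave the same way alongside methyl.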